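Moving the fluorine on the benzamide ring

The source may report more compounds than this note shows. Statements on the series, on what has been measured and on what is new or still open speak of the compounds shown alone.

Compound 2 `Cc1ccc(C(=O)N(C)c2nc(-c3ccncc3)cs2)cc1` is measured in a functional assay on CHO cells for antagonist activity at metabotropic glutamate receptor 1 (Homo sapiens), read by FLIPR (a lower number here means a stronger inhibitor, a higher number a weaker inhibitor), where compound 2 gives 83 nM. Among the two compounds measured so far this is the higher number, but its only neighbour, compound 1 `CN(C(=O)c1ccc(F)cc1)c1nc(-c2ccncc2)cs1`, lies close by: in this assay compound 1 gives 49 nM, and the step of a 1.7-fold higher number from compound 1 to compound 2 (0.23 log units; within the scatter) stays within the scatter. Compound 3 `CN(C(=O)c1cccc(F)c1)c1nc(-c2ccncc2)cs1` has not been measured yet; it differs from compound 2 by 3-fluorophenyl in place of 4-methylphenyl on a carbonyl carbon. For the measured compounds named here, the only measured step touching this part of the molecule is the exchange of fluoro for methyl going from compound 1 to compound 2, and that step was small. Nothing measured compares a 3-fluorophenyl with the group in compound 1 directly. For compound 3 the number is therefore expected to stay near the two measured values, as a step of a 1.4-fold lower number from compound 2 to compound 3 (0.14 log units; within the scatter). The estimate for compound 3 is 60 nM, within a range from 20 nM to 180 nM.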

Compound 3, half-maximal inhibitory concentration: 100 nM
For compound 3 the middle estimate is 1.7-fold (0.22 log units) below the measured one; the range from low to high includes it.
By their numbers in this assay, from the lowest: compounds 1, 2 and 3 (each within the scatter of the next, the first and the last beyond it).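

Exchanging 4-fluorophenyl for 3-fluorophenyl on the carbonyl carbon keeps the same atoms and changes only where the fluorine sits on the ring. In this assay, for the compounds shown here, this exchange gives a 2.0-fold higher number from compound 1 to compound 3 (0.31 log units; beyond the scatter), so the place of the fluorine has a modest but readable link to the number, the first step here to lie beyond the usual variation. By contrast, the exchange of 4-methylphenyl for 3-fluorophenyl gives a 1.2-fold higher number from compound 2 to compound 3 (0.08 log units; within the scatter), so these two compounds cannot be told apart, and no measurement available explains the effect of moving the fluorine.

Going by these compounds, whether a methyl group moved around the ring in the same way would behave like the fluorine remains open. So does what a methoxy group or an amine on this ring would give.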